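Working notes: acetamido in place of bromo, compound 3 to 4

The compounds below may be only part of what the source reports. "The series", "measured", "known", "first", "only" and "open" are said of these compounds alone.

Compound 1 `S=C(Nc1ccccc1)Nc1ccc2[nH]ccc2c1` is the unsubstituted parent of the series; in an assay on cells for inhibition of Amine oxidase [flavin-containing] B (Homo sapiens), read by spectrophotometry (on this read-out higher numbers stand for weaker inhibition and lower numbers for stronger inhibition), compound 1 gives 60000 nM. Compound 2 `Oc1ccc(NC(=S)Nc2ccc3[nH]ccc3c2)cc1` carries a hydroxy group on the aromatic carbon, and in this assay compound 2 gives 17000 nM. Compound 3 `S=C(Nc1ccc(Br)cc1)Nc1ccc2[nH]ccc2c1` carries a bromo group at the same carbon, and compound 3 gives 58000 nM. Of the three numbers compound 3 stands second highest: a 1.0-fold lower number from compound 1 to compound 3 (0.01 log units; within the scatter), so compound 3 and compound 1 cannot be told apart, whereas a 3.4-fold higher number from compound 2 to compound 3 (0.53 log units; beyond the scatter).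

Compound 4 `CC(=O)Nc1ccc(NC(=S)Nc2ccc3[nH]ccc3c2)cc1` has not been measured. The change from compound 3 is acetamido in place of bromo on an aromatic carbon.

Among the compounds with values here, two measured steps bear on this. Putting bromo in place of hydrogen (a 1.0-fold lower number from compound 1 to compound 3 (0.01 log units; within the scatter)) did nothing beyond the scatter, while putting hydroxy in place of hydrogen (a 3.5-fold lower number from compound 1 to compound 2 (0.55 log units; beyond the scatter)) lowered the number modestly; the entering acetamido, like hydroxy, counts one hydrogen-bond donor and one acceptor, unlike bromo. Within the data shown here, with only one substituted compound of each kind, any pattern rests on compound 2 alone.

The expected step is therefore a modest lowering in this assay, a 2.9-fold lower number from compound 3 to compound 4 (0.46 log units; beyond the scatter). For compound 4 the estimated value is 20000 nM, with a range from 7000 nM to 60000 nM.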

Compound 4, half-maximal inhibitory concentration: 37000 nM
Compound 4: middle estimate off by 1.9-fold (0.27 log units), on the low side; the measured number falls inside the stated range.
By their numbers in this assay, from the lowest: compound 2; then compounds 4, 3 and 1 (each within the scatter of the next).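

In this assay, acetamido on this aromatic carbon, para to a large group, cannot be told apart from bromo (a 1.6-fold lower number from compound 3 to compound 4 (0.20 log units; within the scatter)) or from hydrogen (a 1.6-fold lower number from compound 1 to compound 4 (0.21 log units; within the scatter)), whereas the step from hydroxy is beyond the scatter, though modest (a 2.2-fold higher number from compound 2 to compound 4 (0.34 log units; beyond the scatter)). Within the data shown here, the earlier compounds left open whether a group with a hydrogen-bond donor and acceptor would follow hydroxy here; acetamido has the same donor and acceptor counts as hydroxy, yet its number groups with those of compound 1 and compound 3, so these counts alone do not go with the lower number of compound 2, which remains the only compound with steps to all the others beyond the scatter. No measurement shown here explains this separation.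

Going by these compounds, whether the lower number belongs to hydroxy alone remains open, and an amine, a methoxy group or a carboxylic acid on the same carbon would bear on that question. On these data alone, all four compounds share the same core and differ at this one carbon, so how the same groups would behave elsewhere on the core also remains open.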